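Exchanging the Aromatic Ring on the Shared Core

The source may report more compounds than this note shows. Statements on the series, on what has been measured and on what is new or still open speak of the compounds shown alone.

Compound 2, `O=C(O)Cc1sc(C(c2ccc(F)cc2)c2ccc(F)cc2)nc1-c1cc(F)nc(F)c1`, reaches a maximal response of 80% in an in vitro functional assay on HEK285-7 cells for antagonist activity at prostaglandin D2 receptor 2 (Homo sapiens), read by BRET and beta-arrestin recruitment; on this read-out higher numbers stand for larger maximal responses and lower numbers for smaller maximal responses. Its only measured neighbour is compound 1, `O=C(O)Cc1sc(C(c2ccc(F)cc2)c2ccc(F)cc2)nc1-c1ccnc(N2CCCC2)c1`, which in this assay gives 80%, so compound 2 stands level with compound 1 at the digits shown. For the measured compounds named here, the one step recorded so far, no change at the digits printed from compound 1 to compound 2 (within the scatter), exchanged the whole aromatic ring attached to the shared core and left the maximal response unchanged. Compound 3, `O=C(O)Cc1sc(C(c2ccc(F)cc2)c2ccc(F)cc2)nc1-c1ccoc1`, has not yet been measured; it differs from compound 2 by furan-3-yl in place of 2,6-difluoropyridin-4-yl on an aromatic carbon. Because the earlier ring exchange gave no change at the digits printed from compound 1 to compound 2 (within the scatter), a second ring exchange on the same aromatic carbon is expected to produce no step beyond the scatter in this assay, and the expected step is no change at the digits printed from compound 2 to compound 3 (within the scatter). Compound 3 is therefore estimated to reach 80% in this assay, with a likely range from 62% to 95%.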

Compound 3, largest response reached (reported as efficacy), in percent of the reference or control that the assay uses: 80%
Compound 3: the middle estimate sits on the measured number at the digits printed, within the range that was stated.
By their numbers in this assay, from the lowest: compounds 1, 2 and 3 (each within the scatter of the next).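

Placing furan-3-yl on this aromatic carbon, next to the ring nitrogen, gives no change at the digits printed from compound 2 to compound 3 (within the scatter) in this assay even though a five-membered aromatic ring replaces a six-membered one and the group shrinks from 8 heavy atoms to 5. The comparison with the pyrrolidine-bearing ring gives no change at the digits printed from compound 1 to compound 3 (within the scatter) in this assay as well, so three quite different aromatic groups at this position now stand level, and the earlier flat step was not a one-off between two pyridine rings. Nothing available explains why the maximal response stays level across these groups.

The compounds shown leave open whether a group without an aromatic ring, such as a simple amine or a short alkyl chain, would stand level at this carbon. They also leave open whether a larger fused ring such as quinoline would do so.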